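The source may hold more compounds than are shown below. What is called first, only, known or untested is meant among the compounds shown, and "the series" means these compounds.

Measured in an ADME assay on Caco-2 cells (Homo sapiens) for permeability, in the apical to basolateral direction; a higher number here means that the compound crosses the layer faster, a lower number that the compound crosses the layer more slowly:
- compound 1 `Cc1nc(-c2nc[nH]n2)ccc1-c1cnc2c(n1)N([C@H]1CC[C@@H](O)CC1)C(=O)CN2`: 1.6 10^-6 cm/s
- compound 2 `Cc1nc(-c2nc[nH]n2)ccc1-c1cnc2c(n1)N(C(C)C)C(=O)CN2`: 37.6 10^-6 cm/s

Of these two compounds, compound 2 stands higher, at 37.6 10^-6 cm/s. The next compound to be tested is compound 3 `CO[C@H]1CC[C@H](N2C(=O)CNc3ncc(-c4ccc(-c5nc[nH]n5)nc4C)nc32)CC1`, which carries 4-methoxycyclohexyl in place of isopropyl on an amide-type nitrogen in a ring.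

Among the measured compounds shown here, only one measured step bears on this change. Going a 24-fold higher number from compound 1 to compound 2 (1.37 log units; beyond the scatter), isopropyl took the place of 4-hydroxycyclohexyl on that same nitrogen. Compound 3 reverses this direction in part, swapping isopropyl for a cyclohexyl group again. However, its 4-methoxycyclohexyl is not the 4-hydroxycyclohexyl of compound 1, and no measured compound carries it, so one step is a thin guide to the size of the change.

For the measured compounds named here, a lower number in this assay is therefore expected, with a drop beyond the scatter but smaller than the one step seen so far. The expected step is a 4.7-fold lower number from compound 2 to compound 3 (0.67 log units; beyond the scatter). For compound 3 the estimated value is 8 10^-6 cm/s, with an expected range of 2.5 10^-6 cm/s to 25 10^-6 cm/s.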

Compound 3, apparent permeability: 9.7 10^-6 cm/s
The estimate for compound 3 lay 1.2-fold (0.08 log units) below the measured number; low and high end bracket the measured number.
By their numbers in this assay, from the lowest: compound 1; then compound 3; then compound 2.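

In this assay, this amide-type ring nitrogen now has three groups to compare, and a large cyclohexyl-based group no longer means a number as low as that of compound 1. Putting 4-methoxycyclohexyl in place of isopropyl still costs something, with a 3.9-fold lower number from compound 2 to compound 3 (0.59 log units; beyond the scatter), so both cyclohexyl compounds sit below the isopropyl compound. The new information lies in the comparison of the two rings: exchanging 4-hydroxycyclohexyl for 4-methoxycyclohexyl gives a 6.1-fold higher number from compound 1 to compound 3 (0.78 log units; beyond the scatter), so what sits at the far end of the ring matters in this assay, and not only whether a ring is present. No measurement shown explains why these numbers move as they do.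

A plain cyclohexyl group with no oxygen would show how much of the drop from isopropyl goes with the ring alone and how much with the oxygen-bearing group on it. A 4-aminocyclohexyl or a 4-carboxycyclohexyl group would show whether the number falls as far as it does for compound 1 with other end groups on the same ring.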